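Swapping the sulfonamide side chain of compound 3 for isopropyl

The compounds below may be only part of what the source reports. "The series", "measured", "known", "first", "only" and "open" are said of these compounds alone.

Three acids sharing one core have been measured in an assay on CHO cells for displacement of a labelled ligand from prostaglandin D2 receptor 2 (Homo sapiens), read by scintillation counting; on this read-out lower numbers stand for stronger inhibition and higher numbers for weaker inhibition. Compound 1 `COCCN(C)S(=O)(=O)c1ccc(C)c(C#Cc2cc(Cl)ccc2OCC(=O)O)c1` gives 4.1 nM, compound 2 `Cc1ccc(S(=O)(=O)N2CCN(C)CC2)cc1C#Cc1cc(Cl)ccc1OCC(=O)O` gives 21 nM, and compound 3 `COCCNS(=O)(=O)c1ccc(C)c(C#Cc2cc(Cl)ccc2OCC(=O)O)c1` gives 3.6 nM, the lowest of the three numbers, yet separated from compound 1 only by a 1.1-fold lower number from compound 1 to compound 3 (0.06 log units; within the scatter), which lies within the scatter. The change of sulfonyl substituent was costlier: a 5.1-fold higher number from compound 1 to compound 2 (0.71 log units; beyond the scatter) and a 5.8-fold lower number from compound 2 to compound 3 (0.77 log units; beyond the scatter). Compound 4 `Cc1ccc(S(=O)(=O)NC(C)C)cc1C#Cc1cc(Cl)ccc1OCC(=O)O` differs from compound 3 by isopropyl in place of 2-methoxyethyl on a sulfonamide nitrogen. Among the measured compounds shown here, no measured step covers exactly this swap; the nearest, the step from compound 1 to compound 3 at the same nitrogen, was small, so a step in this assay of no more than modest size, if any beyond the scatter, is expected, as a 1.4-fold higher number from compound 3 to compound 4 (0.14 log units; within the scatter). Compound 4 is therefore estimated at 5 nM, within a range of 2 nM to 15 nM.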

Compound 4, inhibition constant: 3.4 nM
Compound 4: middle estimate off by 1.5-fold (0.17 log units), on the high side; the measured number falls inside the stated range.
By their numbers in this assay, from the lowest: compounds 4, 3 and 1 (each within the scatter of the next); then compound 2.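

In this assay a plain isopropyl can take the place of 2-methoxyethyl on the sulfonamide nitrogen, with a 1.1-fold lower number from compound 3 to compound 4 (0.02 log units; within the scatter) as the result, so the ether oxygen of that chain is not needed to hold the number. Set against the N-methylated side chain, the isopropylamino group gives a 1.2-fold lower number from compound 1 to compound 4 (0.08 log units; within the scatter) as well, while a 6.2-fold lower number from compound 2 to compound 4 (0.79 log units; beyond the scatter) leaves 4-methylpiperazin-1-yl as the only group apart from the others. Nothing available here explains why these side chains read alike.
On these data alone, whether a tert-butyl group, a longer chain or a terminal amine on this nitrogen would keep the number remains open.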